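Aryl substituent change on the oxadiazole-linked glycinamide series

The source may report more compounds than this note shows. Statements on the series, on what has been measured and on what is new or still open speak of the compounds shown alone.

Compound 1 `Cc1ccc(-c2nnc(CNC(=O)CN)o2)cc1` is the reference. In an assay for inhibition of histone deacetylase 8 (Homo sapiens), read by fluorescence, with a stated time of 15 min (on this read-out lower numbers stand for stronger inhibition and higher numbers for weaker inhibition), compound 1 gives 139 nM, the second highest of the three numbers, with compound 2 `Cc1ccc(-c2nnc(CNC(=O)[C@@H](C)N)o2)cc1` at 121 nM and compound 3 `COc1ccc(-c2nnc(CNC(=O)[C@@H](C)N)o2)cc1` at 153 nM both within the scatter of it. The step from compound 1 to compound 2, a 1.1-fold lower number from compound 1 to compound 2 (0.06 log units; within the scatter), is methyl in place of hydrogen on a saturated chain carbon bound to an amine nitrogen and a carbonyl carbon. The step from compound 2 to compound 3, a 1.3-fold higher number from compound 2 to compound 3 (0.10 log units; within the scatter), is methoxy in place of methyl on an aromatic carbon.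

Compound 4 `NCC(=O)NCc1nnc(-c2ccc([N+](=O)[O-])cc2)o1` differs from compound 1 by nitro in place of methyl on an aromatic carbon. Among the measured compounds shown here, the only step that bears on the aromatic substituent is the one from compound 2 to compound 3, which stayed within the scatter; nothing measured addresses a nitro group. The expectation for compound 4 is therefore no step beyond the scatter in this assay, a 1.1-fold higher number from compound 1 to compound 4 (0.03 log units; within the scatter), with wide uncertainty. Compound 4 is estimated at 150 nM, range 55 nM to 420 nM.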

Compound 4, half-maximal inhibitory concentration: 134 nM
Beside the measured number, compound 4's estimate is 1.1-fold (0.05 log units) above it; measured number inside the range.
By their numbers in this assay, from the lowest: compounds 2, 4, 1 and 3 (each within the scatter of the next).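

At the aromatic carbon para to a large group, nitro in place of methyl gives a 1.0-fold lower number from compound 1 to compound 4 (0.02 log units; within the scatter) in this assay, so the step stays within the scatter even though the entering group is larger by heavy-atom count and brings hydrogen-bond acceptors. The earlier aromatic change, a 1.3-fold higher number from compound 2 to compound 3 (0.10 log units; within the scatter), was read only with the methyl-bearing chain of compound 2, whereas this one is read with the unbranched chain of compound 1, so two different replacements of this methyl on two different chains have now left the number within the scatter. No measurement on hand bears on why this position tolerates the change.

Going by these compounds, whether an amine, a carboxylic acid or a bulkier group such as phenyl at this carbon would also stay within the scatter remains open. On these data alone, it is also open whether nitro behaves the same way with the methyl-bearing chain of compound 2.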